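Taking one fluoro group off compound 3

The source may hold more compounds than are shown below. What is called first, only, known or untested is meant among the compounds shown, and "the series" means these compounds.

In a functional assay on the whole organism with Mus musculus as the target (a higher number here means that more compound is needed for the effect, a lower number that less compound is needed), compound 3 `O=C(/C=C1\CCc2c1ccc(F)c2F)NC1CC1` gives 62 mg/kg. Compound 2 `O=C(/C=C1\CCc2cc(F)cc(F)c21)NC1CC1`, at 69 mg/kg, lies within the scatter of compound 3. Compound 1 `O=C(/C=C1\CCc2ccccc21)NC1CC1`, at 150 mg/kg, has a higher number, and its distance from compound 3 is beyond the scatter.

Compound 4 `O=C(/C=C1\CCc2cc(F)ccc21)NC1CC1` is still unmeasured in this assay. Its difference from compound 3 is hydrogen in place of fluoro on an aromatic carbon. Compound 4 keeps a fluoro group, whereas compound 1, which has none, gives 150 mg/kg. A value between those of compound 3 and compound 1 therefore seems likely. The expected step is a modest rise, a 1.5-fold higher number from compound 3 to compound 4 (0.16 log units; within the scatter), probably within the scatter. For compound 4 the estimate is 90 mg/kg, with an expected range of 50 mg/kg to 160 mg/kg.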

Compound 4, dose for half-maximal effect: 81 mg/kg
For compound 4 the middle estimate is 1.1-fold (0.05 log units) above the measured one, and the stated range covers the measured number.
By their numbers in this assay, from the lowest: compounds 3, 2, 4 and 1 (each within the scatter of the next, the first and the last beyond it).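

In this assay, hydrogen in place of fluoro on this aromatic carbon (a 1.3-fold higher number from compound 3 to compound 4 (0.12 log units; within the scatter)) and the same exchange on the other fluoro-bearing carbon (a 1.2-fold higher number from compound 2 to compound 4 (0.07 log units; within the scatter)) match the remaining single step, fluoro in place of hydrogen (a 1.9-fold lower number from compound 1 to compound 4 (0.27 log units; within the scatter)), in that none leaves the scatter. No single fluoro exchange among these compounds therefore separates two of them, and this position shows no readable preference for fluoro over hydrogen. Nothing measured bears on the reason for these steps.

From the compounds shown here alone, whether a chloro or methoxy group on this carbon would give a step beyond the scatter remains open.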